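Moving the nitro group on a dihydropyridine calcium channel blocker

The source may hold more compounds than are shown below. What is called first, only, known or untested is meant among the compounds shown, and "the series" means these compounds.

Of the compounds shown here, two have been tested in a functional assay on HEK293 cells for antagonist activity at Voltage-dependent L-type calcium channel subunit alpha-1D (Rattus norvegicus), read by FLIPR; a higher number here means a weaker inhibitor, a lower number a stronger inhibitor. Compound 1 `CCCC1=C(C(=O)OCC)C(c2cccc([N+](=O)[O-])c2)C(C(=O)OCC)=C(C)N1` gives 105 nM. Compound 2 `C=CCOC(=O)C1=C(C)NC(C)=C(C(=O)OC)C1c1ccccc1[N+](=O)[O-]` gives 10 nM, the lowest number of the two, and the gap to compound 1 is well beyond the scatter of repeated measurements, so compound 2 is the stronger inhibitor of the pair.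

Compound 3 `C=CCOC(=O)C1=C(C)NC(C)=C(C(=O)OC)C1c1cccc([N+](=O)[O-])c1` has not yet been measured. It keeps every atom of compound 2 but joins them differently: 3-nitrophenyl in place of 2-nitrophenyl on a saturated ring carbon. Going by the values given here, no measured pair in this set isolates that single change, so the expectation must rest on the general picture that compounds of this shape act well in this assay. For compound 3 the step of a 1.2-fold higher number from compound 2 to compound 3 (0.08 log units; within the scatter) is expected to stay within the scatter, neither clearly stronger nor weaker. Compound 3 is estimated at 12 nM, with a range from 3 nM to 50 nM.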

Compound 3, half-maximal inhibitory concentration: 15 nM
Beside the measured number, compound 3's estimate is 1.3-fold (0.10 log units) below it, and the stated range covers the measured number.
By their numbers in this assay, from the lowest: compounds 2 and 3 (each within the scatter of the next); then compound 1.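

In this assay, going by these compounds alone, 3-nitrophenyl in place of 2-nitrophenyl on the saturated ring carbon gives a 1.5-fold higher number from compound 2 to compound 3 (0.18 log units; within the scatter) and is the first change here read with everything else held fixed. Compound 1 and compound 2 differ in more than one place, so their gap could not show what the nitro group's placement alone does; this pair shows that the two placements cannot be told apart in this assay. Nothing available here explains why the two placements read alike.

Still open, from the compounds shown here alone, is whether the nitro group matters at all, since a phenyl ring carrying a nitrile or an amine in its place would test that directly. Also open, going by these compounds, is how a longer chain in place of the allyloxycarbonyl group would read with either nitrophenyl.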